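The compounds below may be only part of what the source reports. "The series", "measured", "known", "first", "only" and "open" are said of these compounds alone.

Measured so far in a functional assay on NCI-H1581 cells (Homo sapiens) for inhibition, read by MTT assay, with a stated time of 48 h, tested at 10 uM; on this read-out higher numbers stand for more inhibition at the one concentration tested (going by the name of the read-out) and lower numbers for less inhibition:
compound 1 `COc1cc(NC(=O)Nc2cc(Nc3ccc(OC)c(C)c3)ncn2)cc(OC)c1` gives 19.7%;
compound 2 `COc1ccc(OC)c(Nc2cc(NC(=O)Nc3c(Cl)cccc3Cl)ncn2)c1` gives 93.1%;
compound 3 `O=C(Nc1cc(Nc2ccc(F)c(Cl)c2)ncn1)Nc1c(Cl)cccc1Cl` gives 67%.

Compound 1 stands lowest of the three numbers in this assay; compound 3 is the nearer of the other two and compound 2 the further, and both gaps lie beyond the scatter. For the measured compounds named here, compounds 2 and 3 each differ from compound 1 in more than one place, so no single step between measured compounds is available.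

Compound 4 `COc1cc(NC(=O)Nc2cc(Nc3ccc(Br)cc3OC)ncn2)cc(OC)c1` is the unmeasured analogue of compound 1: 4-bromo-2-methoxyphenyl in place of 4-methoxy-3-methylphenyl on a nitrogen on an aromatic ring. Going by the values given here, no measured pair isolates this change, so its size is uncertain. The estimated step is a number 13.3 percentage points higher from compound 1 to compound 4 (beyond the scatter), a modest rise that may not exceed the scatter. Compound 4 is accordingly expected to give about 33% in this assay, within 10% to 62%.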

Compound 4, a percentage reported as inhibition, at one concentration (the size of the read-out at that concentration, not a potency): 20.1%
Estimate against measurement, compound 4: 12.9 percentage points above, within the range that was stated.
By their numbers in this assay, from the lowest: compounds 1 and 4 (each within the scatter of the next); then compound 3; then compound 2.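

Placing 4-bromo-2-methoxyphenyl in place of 4-methoxy-3-methylphenyl on a nitrogen on an aromatic ring gives the only single-place comparison in this assay: a number 0.4 percentage points higher from compound 1 to compound 4 (within the scatter). On the core of compound 1, the number in this assay therefore stays level across this exchange, with no change beyond the scatter. Nothing available explains this flat step.

From the compounds shown here alone, whether the same exchange stays as flat with the other urea partner, carried by compound 2 and compound 3, remains open. Also open, going by these compounds, is whether a carboxylic acid or a morpholine on this ring would move the read-out.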